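Ethoxymethyl in place of propoxycarbonyl on the shared core

The compounds below may be only part of what the source reports. "The series", "measured", "known", "first", "only" and "open" are said of these compounds alone.

Compound 1 `CCCOC(=O)c1c(C)coc1-c1ccc2c(CC)cccc2c1OC` is known only as a limit: in a functional assay on SK-BR-3 cells (Homo sapiens) for cytotoxicity, read by MTT assay, with a stated time of 72 h (on this read-out higher numbers stand for an effect only at larger amounts of compound and lower numbers for an effect already at smaller amounts), compound 1 gives > 10 ug/mL. Compound 2 `CCc1cccc2c(OC)c(-c3occ(C)c3C(=O)On3nnc4ccccc43)ccc12` also stands at a limit, giving > 10 ug/mL in this assay. The step that the two limits leave unreadable from compound 1 to compound 2 thus cannot be sized, and the limit of > 10 ug/mL in this assay, at which 2 of the 2 values shown sit, is all the two share. Compound 3 `CCOCc1c(C)coc1-c1ccc2c(CC)cccc2c1OC` carries ethoxymethyl in place of propoxycarbonyl on an aromatic carbon. Within the data shown here, no measured step bears on this change, so the expectation for compound 3 rests only on where compound 1 sits and on (the limit of > 10 ug/mL in this assay, at which 2 of the 2 values shown sit); a step that the limit leaves unreadable from compound 1 to compound 3 is estimated, with no direction beyond the scatter. Compound 3 is expected to give 15 ug/mL in this assay, between 5 ug/mL and 50 ug/mL.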

Compound 3, concentration for half-maximal effect: > 10 ug/mL
Compound 3: a limit, no number; the forecaster's own chance of this, stated with the estimate: 70%; the middle value is on the limit's open side.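

Compound 1 and compound 3 both stand at a limit in this assay, and the step between them cannot be read. The compounds shown leave open what ethoxymethyl in place of propoxycarbonyl changes, if anything, and how far any compound lies from the limit.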